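Lengthening the chain of compound 1 to compound 3

The compounds below may be only part of what the source reports. "The series", "measured", "known", "first", "only" and "open" are said of these compounds alone.

Within the data shown here, in a functional assay on brain (Rattus norvegicus, strain Wistar) for inhibition (on this read-out higher numbers stand for weaker inhibition and lower numbers for stronger inhibition), compound 1 (`CCCc1ccc(-c2c(C)[nH]c(=O)n2C)cc1`) gives 21500 nM, the higher of the two numbers so far, and compound 2 (`CCCCCCOc1ccc(-c2c(C)[nH]c(=O)n2C)cc1`) gives 7300 nM. Compound 3 (`CCCCCCCCc1ccc(-c2c(C)[nH]c(=O)n2C)cc1`) differs from compound 1 by pentyl in place of hydrogen on a saturated chain carbon, three bonds along the chain from an aromatic carbon, with pentyl in place of hydrogen on a saturated chain carbon, three bonds along the chain from an aromatic carbon. Among the measured compounds shown here, the only measured step bearing on this is the modest 2.9-fold lower number from compound 1 to compound 2 (0.47 log units; beyond the scatter), with hexyloxy in place of propyl on an aromatic carbon. For the measured compounds named here, no measured step extends a plain alkyl chain. A similarly modest move to a lower number is expected, estimated as a 3.3-fold lower number from compound 1 to compound 3 (0.52 log units; beyond the scatter). Compound 3 is estimated at 6500 nM, within a range of 2000 nM to 20000 nM.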

Compound 3, half-maximal inhibitory concentration: 19400 nM
Compound 3: the middle estimate sits 3.0-fold (0.47 log units) below what was measured, within the range that was stated.
By their numbers in this assay, from the lowest: compound 2; then compounds 3 and 1 (each within the scatter of the next).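

Pentyl in place of hydrogen on a saturated chain carbon, three bonds along the chain from an aromatic carbon, gives a 1.1-fold lower number from compound 1 to compound 3 (0.04 log units; within the scatter), so the 5 added carbons leave compound 3 within the scatter of compound 1. Added alkyl length alone therefore does not reproduce a 2.9-fold lower number from compound 1 to compound 2 (0.47 log units; beyond the scatter), the one step beyond the scatter, where hexyloxy replaces propyl. Open, on these data alone, is whether a plain hexyl chain, a shorter methoxy group or a terminal amine or carboxylic acid on the chain would shift the number. Nothing available explains this flat result.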